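Aromatic substituent change and permeability in one series

The compounds below may be only part of what the source reports. "The series", "measured", "known", "first", "only" and "open" are said of these compounds alone.

compound 1 `CC(C)c1ccc(NC2=NCCC3(CCCCC3)S2)cc1` — 15.7 10^-6 cm/s
compound 2 `COc1ccc(NC2=NCCC3(CCCCC3)S2)cc1` — 1.11 10^-6 cm/s

Going by the values given here, in a physicochemical assay for permeability (on this read-out higher numbers stand for higher permeability and lower numbers for lower permeability), compound 1 gives 15.7 10^-6 cm/s and compound 2 gives 1.11 10^-6 cm/s; compound 2 thus has the lowest number of the two, the only measured step being a 14-fold lower number from compound 1 to compound 2 (1.15 log units; beyond the scatter). Compound 3 `CC(=O)c1ccc(NC2=NCCC3(CCCCC3)S2)cc1` differs from compound 2 by acetyl in place of methoxy on an aromatic carbon. Among the compounds with values here, no measured step exchanges one oxygen-bearing group for another; the single step, large and downward, concerns the isopropyl and does not bear directly on this change. Thus only a step within the scatter is expected for compound 3: a 1.1-fold lower number from compound 2 to compound 3 (0.05 log units; within the scatter). For compound 3 the estimate is 1 10^-6 cm/s, between 0.4 10^-6 cm/s and 2.5 10^-6 cm/s.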

Compound 3, apparent permeability: 2.55 10^-6 cm/s
Estimate against measurement, compound 3: 2.6-fold (0.41 log units) below, outside the stated range (above it).
By their numbers in this assay, from the lowest: compound 2; then compound 3; then compound 1.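

In this assay the exchange of methoxy for acetyl gives a 2.3-fold higher number from compound 2 to compound 3 (0.36 log units; beyond the scatter) and so counts as a real, modest change at this aromatic carbon. Acetyl does not reach the isopropyl level, with a 6.2-fold lower number from compound 1 to compound 3 (0.79 log units; beyond the scatter) on that exchange, so the three groups give three separate levels. Nothing available accounts for these differences. As far as these compounds go, whether an amine, a carboxylic acid or a longer alkyl chain on this carbon would fall inside or outside this span stays open. From the compounds shown here alone, whether the same order of groups holds on another core is also open.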